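Trifluoromethyl step repeated on a second core

This account rests on a few compounds, and the source may have more. Where it says the series, first, only, none or still open, it means among the compounds named here.

Compound 1 `C=C(Br)C(=O)Nc1ccc(/C=C2\SC(=O)N(Cc3ccccc3)C2=O)cc1` is measured in a functional assay on FM3A cells (Mus musculus) for cytotoxicity, read by cell counting, with a stated time of 2 days (a higher number here means a weaker inhibitor, a lower number a stronger inhibitor), and gives 3000 nM. Compound 2 `C=C(Br)C(=O)Nc1ccc(/C=C2\SC(=O)N(Cc3ccc(C(F)(F)F)cc3)C2=O)cc1` carries the change (trifluoromethyl in place of hydrogen on an aromatic carbon); in this assay compound 2 gives 23000 nM, which makes the step of a 7.7-fold higher number from compound 1 to compound 2 (0.88 log units; beyond the scatter). Compound 3 `Nc1cccc(/C=C2\SC(=O)N(Cc3ccccc3)C2=O)c1` sits at the limit of > 250000 nM in this assay, at which 1 of the 3 values shown sits: in this assay compound 3 gives > 250000 nM, a limit of the assay and not a number. The difference between the cores of compound 1 and compound 3 is not broken down here. Compound 4 `Nc1cccc(/C=C2\SC(=O)N(Cc3ccc(C(F)(F)F)cc3)C2=O)c1` is not yet measured; it differs from compound 3 by trifluoromethyl in place of hydrogen on an aromatic carbon, the same change as from compound 1 to compound 2, at a place described in the same words. Compound 4 is expected to fall beyond the same limit, with the step that the limit leaves unreadable from compound 3 to compound 4 estimated from the weakening in a 7.7-fold higher number from compound 1 to compound 2 (0.88 log units; beyond the scatter). The estimate for compound 4 in this assay is 300000 nM, between 150000 nM and 1000000 nM, most likely reported only as a limit.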

Compound 4, half-maximal inhibitory concentration: > 250000 nM
Compound 4 was reported as a limit (the forecaster's own chance of this, stated with the estimate: 90%); the middle value does not contradict the limit.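

Within the data shown here, compound 3 and compound 4 both stand at a limit in this assay, so no step between them can be read: the limit of > 250000 nM in this assay, at which 2 of the 4 values shown sit.
From the compounds shown here alone, whether trifluoromethyl in place of hydrogen shifts the number on the core of compound 3 as it does on the core of compound 1 stays open.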